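Benzyl for methyl on selenium in an isoselenourea series

This account rests on a few compounds, and the source may have more. Where it says the series, first, only, none or still open, it means among the compounds named here.

Measured compounds:
compound 1 `CS/C(=N\C(=O)c1ccno1)NC(=O)c1ccno1`: > 100000 nM
compound 2 `CS/C(=N\C(=O)c1cc(-c2ccccc2)nc2ccccc12)NC(=O)c1cc(-c2ccccc2)nc2ccccc12`: 6240 nM
compound 3 `C[Se]/C(=N\C(=O)c1cnc2ccccc2c1)NC(=O)c1cnc2ccccc2c1`: 4160 nM

Three diacyl isothiourea or isoselenourea compounds have been tested in a functional assay on HepG2 cells (Homo sapiens) for cytotoxicity, read by MTT assay, with a stated time of 72 h; on this read-out lower numbers stand for stronger inhibition of growth and higher numbers for weaker inhibition of growth. In this assay compound 1 gives only a limit, > 100000 nM, and not a number. Compound 2 gives 6240 nM in this assay. Compound 3, the selenium-bearing member with a methyl group on the selenium, gives 4160 nM in this assay, which is the lower of the two numbers reported; its gap to compound 2 is within the scatter of repeated measurements, so no order between compound 2 and compound 3 can be read from it.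

The next compound to be measured is compound 4 `O=C(/N=C(/NC(=O)c1cnc2ccccc2c1)[Se]Cc1ccccc1)c1cnc2ccccc2c1`. It differs from compound 3 by phenyl in place of hydrogen on a saturated chain carbon bound to a selenium atom. Going by the values given here, no pair of measured compounds shows the effect of this change, so no measured step is available to anchor an expectation. On the numbers shown, the step from compound 3 to compound 4 in this assay is expected to be small, a 1.4-fold lower number from compound 3 to compound 4 (0.14 log units; within the scatter), and not clearly beyond the scatter in either direction. Compound 4 is therefore estimated at 3000 nM in this assay, with a range from 800 nM to 12000 nM.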

Compound 4, concentration for 50% growth inhibition: 8540 nM
Compound 4: the middle estimate sits 2.8-fold (0.45 log units) below what was measured; low and high end bracket the measured number.
By their numbers in this assay, from the lowest: compounds 3, 2 and 4 (each within the scatter of the next, the first and the last beyond it). At a limit, above all of these: compound 1.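

In this assay, the position on selenium proves not to be indifferent to substitution: the change from methyl to benzyl, with phenyl in place of hydrogen on a saturated chain carbon bound to a selenium atom, gives a 2.1-fold higher number from compound 3 to compound 4 (0.31 log units; beyond the scatter), a modest loss of growth inhibition that lies just beyond the scatter. The earlier compounds shown here could not show this, since no two of them differed in one place, and this pair now gives the series its first single-change comparison, showing that the larger group on selenium is tolerated with only a modest penalty and brings no gain in this assay. Nothing in the data shown accounts for the direction or size of this step.

From the compounds shown here alone, whether the step follows from the aromatic ring itself or from the size of the group remains open, as a single pair cannot separate the two, and an ethyl group, a longer chain or a phenethyl group on selenium would be needed to tell them apart. Also open, going by these compounds, is whether a benzyl group on sulfur in place of selenium, or a benzyl ring carrying a methoxy group or an amine, would move the number in the same direction.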